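Adding a Methyl to the Chain of Compound 1

The source may hold more compounds than are shown below. What is called first, only, known or untested is meant among the compounds shown, and "the series" means these compounds.

Compound 1 `CN1C(=O)N(C)C2C1NC(=S)N2/N=C/C=C/c1ccccc1` was examined in a functional assay on MCF7 cells (Homo sapiens) for inhibition, read by MTT assay, with a stated time of 72 h; on this read-out lower numbers stand for stronger inhibition and higher numbers for weaker inhibition. In this assay compound 1 gives > 100000 nM, a value that is a limit of the assay rather than a number. Two measured neighbours differ from compound 1 in one place on the aromatic ring. Compound 2 `CN1C(=O)N(C)C2C1NC(=S)N2/N=C/C=C/c1ccccc1[N+](=O)[O-]` carries a nitro in place of hydrogen on an aromatic carbon, and in this assay compound 2 gives 1760 nM; the step is an at least 56-fold lower number from compound 1 to compound 2 (1.75 log units; beyond the scatter). Compound 3 `COc1ccc(/C=C/C=N/N2C(=S)NC3C2N(C)C(=O)N3C)cc1` carries a methoxy in place of hydrogen on an aromatic carbon. In this assay compound 3 gives > 100000 nM, which is again a limit of the assay. The step that the two limits leave unreadable from compound 1 to compound 3 cannot be read because both values sit at the limit of > 100000 nM in this assay, at which 2 of the 3 values shown sit.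

Compound 4 `CC(/C=N/N1C(=S)NC2C1N(C)C(=O)N2C)=C\c1ccccc1` differs from compound 1 not on the ring but on the chain: methyl in place of hydrogen on a double-bonded chain carbon bound to a carbon with a double bond to nitrogen and a double-bonded chain carbon. Neither measured step touches that position, so neither bears directly on this change; the only large movement seen came with the nitro group of compound 2, while the methoxy group of compound 3 produced no readable step. For compound 4 the expected step is a number no higher from compound 1 to compound 4 (the limit leaves the size open). Compound 4 is therefore estimated at 100000 nM in this assay, within a range of 20000 nM to 400000 nM.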

Compound 4, half-maximal inhibitory concentration: > 100000 nM
Compound 4 was reported as a limit (the forecaster's own chance of this, stated with the estimate: 70%); the middle value lies on the limit itself.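

In this assay compound 4 gives > 100000 nM, which is a limit of the assay and not a number. No step from compound 1 to compound 4 can be read, because both values sit at the same limit: the limit of > 100000 nM in this assay, at which 3 of the 4 values shown sit.

The compounds shown leave open what the methyl on the chain does to inhibition when the value of the parent compound is not a limit.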